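The source may report more compounds than this note shows. Statements on the series, on what has been measured and on what is new or still open speak of the compounds shown alone.

In a functional assay on SW-620 cells (Homo sapiens) for cytotoxicity, read by MTT assay, with a stated time of 48 h (on this read-out higher numbers stand for weaker inhibition and lower numbers for stronger inhibition), two compounds have been measured so far. Compound 1 `CCCCCCCCNC(=O)[C@@H](NC(=O)c1nccc2ccccc12)[C@@H](C)O` gives 67800 nM in this assay, and compound 2 `CCCCCCCCCCCCNC(=O)[C@@H](NC(=O)c1cccs1)[C@@H](C)O` gives 29200 nM. Compound 2 therefore has the lower of the two numbers, and its gap to compound 1 is wider than the usual scatter of this assay. Compound 3 `C/C=C/C=C/C(=O)N[C@H](C(=O)NCCCCCCCCCCCC)[C@@H](C)O` has not yet been measured. It keeps the shared core of compound 2 unchanged except at one place: penta-1,3-dien-1-yl in place of thiophen-2-yl on a carbonyl carbon. Among the measured compounds shown here, no measured pair shows what this exchange does, so there is nothing to lean on except the weak numbers of compound 1 and compound 2. The step of a 1.0-fold higher number from compound 2 to compound 3 (0.01 log units; within the scatter) is expected to stay small, with no clear direction beyond the scatter. Compound 3 is thus expected to give about 30000 nM in this assay, with a plausible range from 10000 nM to 90000 nM.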

Compound 3, half-maximal inhibitory concentration: 200000 nM
Compound 3: middle estimate off by 6.7-fold (0.82 log units), on the low side, outside the stated range (above it).
By their numbers in this assay, from the lowest: compound 2; then compound 1; then compound 3.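

In this assay the exchange on this carbonyl carbon gives a 6.8-fold higher number from compound 2 to compound 3 (0.84 log units; beyond the scatter) and so weakens inhibition, which shows that the group at this place matters. The two groups hold the same number of heavy atoms, so this pair shows that size counted this way does not settle the outcome: thiophen-2-yl, with its five-membered aromatic ring and sulfur, and the open penta-1,3-dien-1-yl chain, with its two double bonds, are not interchangeable here. No measurement at hand explains why the number rises.

Whether the ring, the sulfur or the double bonds account for the step remains open. Furan-2-yl, phenyl or a saturated pentyl chain at the same carbonyl carbon would help separate these features.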